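The compounds below may be only part of what the source reports. "The series", "measured", "known", "first", "only" and "open" are said of these compounds alone.

Measured so far, in a functional assay on HT-29 cells (Homo sapiens) for inhibition, read by sulforhodamine B assay, with a stated time of 72 h; a lower number here means a stronger inhibitor, a higher number a weaker inhibitor:
- compound 1 `COc1cc2c(Nc3ccc(OCc4cccc(F)c4)c(Cl)c3)ncnc2cc1OCCCCCn1ccnc1[N+](=O)[O-]`, 14100 nM
- compound 2 `COc1cc2c(Nc3ccc(OCc4cccc(F)c4)c(Cl)c3)ncnc2cc1OCCCCCCn1ccnc1[N+](=O)[O-]`, limit only
- compound 3 `COc1cc2c(Nc3cccc(Br)c3)ncnc2cc1OCCCCCn1ccnc1[N+](=O)[O-]`, 5050 nM

Compound 2 gives > 50000 nM in this assay, which is a limit of the assay and not a number; it sits at the limit of > 50000 nM in this assay, at which 1 of the 3 values shown sits. The change from compound 1 to compound 2 is (2-nitro-1H-imidazol-1-yl)methyl in place of 2-nitro-1H-imidazol-1-yl on a saturated chain carbon, five bonds along the chain from an oxygen on an aromatic ring, and it made an at least 3.5-fold higher number from compound 1 to compound 2 (0.54 log units; beyond the scatter). Compound 3 shares this assay with compound 1 and shows the lower number of the two; the difference between their two cores is not broken down here.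

Compound 4 `COc1cc2c(Nc3cccc(Br)c3)ncnc2cc1OCCCCCCn1ccnc1[N+](=O)[O-]` is not yet measured. It differs from compound 3 by (2-nitro-1H-imidazol-1-yl)methyl in place of 2-nitro-1H-imidazol-1-yl on a saturated chain carbon, five bonds along the chain from an oxygen on an aromatic ring, the same change as from compound 1 to compound 2. Because the measured step was an at least 3.5-fold higher number from compound 1 to compound 2 (0.54 log units; beyond the scatter), a step of like size is expected here, a 4.0-fold higher number from compound 3 to compound 4 (0.60 log units; beyond the scatter), with a real chance of a limit only. Compound 4 is estimated at 20000 nM in this assay, between 8000 nM and 50000 nM.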

Compound 4, half-maximal inhibitory concentration: 10500 nM
Compound 4: middle estimate off by 1.9-fold (0.28 log units), on the high side; low and high end bracket the measured number.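

In this assay the change to (2-nitro-1H-imidazol-1-yl)methyl on the core of compound 3 gives a 2.1-fold higher number from compound 3 to compound 4 (0.32 log units; beyond the scatter) and so runs in the same direction as on the core of compound 1. Direction carries over between these two cores, but equal size is not shown: the same change on two cores in this assay, an at least 3.5-fold higher number (0.54 log units; beyond the scatter) from compound 1 to compound 2 and a 2.1-fold higher number (0.32 log units; beyond the scatter) from compound 3 to compound 4; the limit leaves it open whether they differ.
From the compounds shown here alone, compound 2 at > 50000 nM is a limit of the assay and not a number, so the full step on its core remains unknown.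

The compounds shown leave open how a shorter chain or a longer chain would read on either core. They also leave open whether the same direction holds on a third core, or with an amine in place of the 2-nitro-1H-imidazol-1-yl group.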